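The compounds below may be only part of what the source reports. "The series", "measured", "known", "first", "only" and "open" are said of these compounds alone.

The measured compounds, with their numbers:

compound 1 `Cc1nccc(N2c3ccc(C4(NC(=O)c5ccc(F)cc5)CC4)cc3[C@H]3CC[C@H]32)n1`: 3.8 nM
compound 2 `Cc1nccc(N2CCc3nc(C4(NC(=O)c5ccc(Cl)cc5)CCC4)ccc32)n1`: 46 nM
compound 3 `Cc1nccc(N2c3ccc(C4(NC(=O)c5ccc(F)cc5)CC4)cc3[C@@H]3CC[C@@H]32)n1`: 5 nM

In an assay on HeLa cells for inhibition of Indoleamine 2,3-dioxygenase 1 (Homo sapiens) (a lower number here means a stronger inhibitor, a higher number a weaker inhibitor), compound 1 gives 3.8 nM, the lowest of the three numbers shown. Nearest to it stands compound 3, with a 1.3-fold higher number from compound 1 to compound 3 (0.12 log units; within the scatter); these two compounds share every atom and bond, as the fact that compounds 1 and 3 differ only in the configuration as drawn states, so the pair shows that mirroring the two stereocentres of the saturated ring leaves the number essentially unchanged. Furthest from compound 1 is compound 2, which in this assay gives 46 nM; compound 2 differs from compound 1 in several places at once, so its two values can only be set side by side.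

Compound 4 `COC(=O)N1c2ccc(C3(NC(=O)c4ccc(F)cc4)CC3)cc2[C@H]2CC[C@H]21` is the next compound and differs from compound 1 in one place: methoxycarbonyl in place of 2-methylpyrimidin-4-yl on a nitrogen on an aromatic ring in a ring. Going by the values given here, no measured step bears on this change. The step from compound 1 to compound 3 concerns configuration alone, and compound 2 carries a different core and a different halogen together with other changes, so neither pair speaks to an exchange of the group on the ring nitrogen. The expectation for compound 4 therefore rests on the structural change itself, and a weaker inhibitor is expected, with an 11-fold higher number from compound 1 to compound 4 (1.02 log units; beyond the scatter). For compound 4 in this assay the estimate is 40 nM, within a range from 8 nM to 300 nM.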

Compound 4, half-maximal inhibitory concentration: 2.8 nM
Compound 4: the middle estimate sits 14-fold (1.15 log units) above what was measured; the measured number lies below the stated range.
By their numbers in this assay, from the lowest: compounds 4, 1 and 3 (each within the scatter of the next); then compound 2.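

In this assay the group on the ring nitrogen turns out to be open to a large exchange, with a 1.4-fold lower number from compound 1 to compound 4 (0.13 log units; within the scatter) when methoxycarbonyl replaces 2-methylpyrimidin-4-yl. The earlier compounds shown here gave no step at this position, and this one shows that a group with no ring and fewer heavy atoms, carrying no hydrogen-bond donors and the same count of hydrogen-bond acceptors, gives a number that cannot be told apart from that of the six-membered aromatic ring with its two hetero atoms, so on this core that ring is not required for a number of this size. Nothing measured here bears on why the two groups read alike.

The compounds shown leave open whether a plain amine hydrogen on this nitrogen, an acetyl group or a longer chain such as butoxycarbonyl would hold the number in the same way. They also leave open whether methoxycarbonyl would behave alike on the mirror-image core of compound 3 or on the core of compound 2.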